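Replacing the pentyl chain of compound 1 with ethylamino

The source may report more compounds than this note shows. Statements on the series, on what has been measured and on what is new or still open speak of the compounds shown alone.

Measured compounds:
compound 1, `CCCCCC(=O)Nc1ccc(S(=O)(=O)Oc2ccccc2C(C)C)cc1`, 6700 nM
compound 2, `CCCCCC(=O)Nc1ccc(S(=O)(=O)Oc2ccccc2I)cc1`, 11000 nM
compound 3, `O=C(CCl)Nc1ccc(S(=O)(=O)Oc2ccccc2I)cc1`, 3900 nM

All three values come from a functional assay on M21 cells (Homo sapiens) for antiproliferative activity, read by sulforhodamine B assay, with a stated time of 48 h; a lower number here means a stronger inhibitor, a higher number a weaker inhibitor. Compound 1 gives the second highest of the three numbers; its gap to compound 2, a 1.6-fold higher number from compound 1 to compound 2 (0.22 log units; within the scatter), and its gap to compound 3 both lie within the scatter, so no ordering among the three can be claimed from compound 1 alone.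

The unmeasured compound 4, `CCNC(=O)Nc1ccc(S(=O)(=O)Oc2ccccc2C(C)C)cc1`, differs from compound 1 in one place: ethylamino in place of pentyl on a carbonyl carbon. Within the data shown here, no measured step changes this part of the molecule in the same way. The nearest comparison is the step of a 2.8-fold lower number from compound 2 to compound 3 (0.45 log units; beyond the scatter), where a shorter group took the place of butyl on the same kind of carbonyl carbon and the number fell modestly. That step does not involve an ethylamino group, so it gives only weak guidance. The expected outcome in this assay is a step that stays within the scatter, with a slight lean toward a lower number, a 1.3-fold lower number from compound 1 to compound 4 (0.13 log units; within the scatter). Compound 4 is therefore estimated at 5000 nM, with a range from 1500 nM to 16000 nM.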

Compound 4, half-maximal inhibitory concentration: 4700 nM
For compound 4 the middle estimate is 1.1-fold (0.03 log units) above the measured one, within the range that was stated.
By their numbers in this assay, from the lowest: compounds 3, 4, 1 and 2 (each within the scatter of the next, the first and the last beyond it).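

In this assay, ethylamino in place of pentyl on the carbonyl carbon gives a 1.4-fold lower number from compound 1 to compound 4 (0.15 log units; within the scatter). Among these compounds, the only earlier change at this kind of carbon was chloro in place of butyl, so this is the first sign that this place accepts a group with a nitrogen and a hydrogen-bond donor, and a shorter one of 3 heavy atoms rather than 5, with the result staying within the scatter. No separate measurement is available to explain this result.

Still open, on these data alone, is whether a longer chain on that nitrogen, such as hexylamino, or a ring-bearing group such as anilino would shift the number beyond the scatter. Also open, as far as these compounds go, is whether ethylamino gives a similar result when iodo stands in place of isopropyl on the aromatic carbon.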